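The source may hold more compounds than are shown below. What is called first, only, known or untested is meant among the compounds shown, and "the series" means these compounds.

Measured so far:
- compound 1 `CCCCCCCC/C=C/CCCCCCCC(=O)Nc1ccccc1C(C)C`: 600 nM
- compound 2 `CCCCCCCC/C=C/CCCCCCCC(=O)Nc1ccccc1C(=O)c1ccccc1`: > 10000 nM

In an assay on microsomes from intestine for inhibition of acyl-CoA:cholesterol acyltransferase (Oryctolagus cuniculus) (on this read-out lower numbers stand for stronger inhibition and higher numbers for weaker inhibition), compound 1 gives 600 nM. It holds the only plain number shown; the other value is a limit. For compound 2 the assay reports > 10000 nM, which is a limit of the assay and not a number (the limit of > 10000 nM in this assay, at which 1 of the 2 values shown sits). Within the data shown here, the step of an at least 16-fold higher number from compound 1 to compound 2 (1.22 log units; beyond the scatter) is the sole measured step, and it concerns a different change; it shows only that a benzoyl in that place costs potency heavily.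

Compound 3 `CCCCCCCC/C=C/CCCCCCCC(=O)Nc1c(C)cccc1OC` is not yet measured. Its difference from compound 1 is 2-methoxy-6-methylphenyl in place of 2-isopropylphenyl on an amide-type nitrogen. Among the measured compounds shown here, no measured step covers this exchange: the one known step swaps the isopropyl for a benzoyl, whereas here the whole phenyl is replaced by one that keeps a small methyl and adds a methoxy. With nothing pointing clearly either way, the expectation is a step of no more than modest size in this assay, a 1.2-fold lower number from compound 1 to compound 3 (0.08 log units; within the scatter). Compound 3 is therefore estimated at 500 nM, with a range from 150 nM to 3000 nM.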

Compound 3, half-maximal inhibitory concentration: 20 nM
Compound 3: the middle estimate sits 25-fold (1.40 log units) above what was measured; measured number below the stated range.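

Replacing 2-isopropylphenyl with 2-methoxy-6-methylphenyl on the amide-type nitrogen gives a 30-fold lower number from compound 1 to compound 3 (1.48 log units; beyond the scatter). Among these compounds, the only earlier step at this part of the molecule was a loss, an at least 16-fold higher number from compound 1 to compound 2 (1.22 log units; beyond the scatter), whereas this result shows that a change here can also push the number strongly down in this assay, so the group on the nitrogen can work in either direction. Both groups have the same heavy-atom count and a six-membered aromatic ring of carbon only, and the entering group differs by carrying an oxygen that counts as a hydrogen-bond acceptor, but nothing shown ties the gain to that oxygen or to any other feature.

The exchange alters the aromatic group in more than one way at once, and no compound shown carries the methoxy without the methyl or the methyl without the methoxy, which leaves open whether one of them or the pair accounts for the step. Also open, from the compounds shown here alone, is how an ethoxy group or an amine in place of the methoxy would read in this assay.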